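The compounds below may be only part of what the source reports. "The series", "measured", "known", "first", "only" and "open" are said of these compounds alone.

Measured compounds:
Compound 1, `COc1ccc(/C=C2\CC[C@H]3C(C)(C)CCC[C@]3(C)[C@H]2CCC(C)CC(=O)O)cc1`: in a functional assay on K562 cells (Homo sapiens) for cytotoxicity, read by MTT assay, with a stated time of 72 h (a lower number here means a stronger inhibitor, a higher number a weaker inhibitor), compound 1 gives > 200000 nM, which is a limit of the assay, not a number.
Compound 2, `Cc1ccc(/C=C2\CC[C@H]3C(C)(C)CCC[C@]3(C)[C@H]2CCC(C)CC(=O)O)cc1`: in this assay compound 2 gives > 200000 nM, again a limit.
Compound 3, `CC(CC[C@H]1/C(=C/c2ccc(Cl)cc2)CC[C@H]2C(C)(C)CCC[C@]12C)CC(=O)O`: in this assay compound 3 gives > 200000 nM, again a limit.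

Compound 1 therefore stands at the limit, together with every other measured compound, all three sitting at the limit of > 200000 nM in this assay, at which 3 of the 3 values shown sit. The unmeasured compound 4, `CC(CC[C@H]1/C(=C/c2ccc(I)cc2)CC[C@H]2C(C)(C)CCC[C@]12C)CC(=O)O`, differs from compound 1 in one place: iodo in place of methoxy on an aromatic carbon. The measured steps that bear on this are those that change the same group on the same aromatic carbon, a step that the two limits leave unreadable from compound 1 to compound 2 and a step that the two limits leave unreadable from compound 1 to compound 3; the third step, a step that the two limits leave unreadable from compound 2 to compound 3, is of the same kind. None of them can be sized, because both ends sit at the limit of > 200000 nM in this assay, at which 3 of the 3 values shown sit. Going by the values given here, there is thus no measured step that would point to compound 4 leaving the limit in either direction, and no step beyond the scatter is expected. Compound 4 is expected at 300000 nM, between 100000 nM and 1000000 nM, most likely reported as a limit like its neighbours. The expected step from compound 1 to compound 4 is a step that the limit leaves unreadable from compound 1 to compound 4.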

Compound 4, half-maximal inhibitory concentration: 55000 nM
Beside the measured number, compound 4's estimate is 5.5-fold (0.74 log units) above it, outside the stated range (below it).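

The three earlier steps cannot be read, because both ends of each sit at a limit: the limit of > 200000 nM in this assay, at which 3 of the 4 values shown sit. In this assay, iodo on this aromatic carbon gives the first readable change, with iodo in place of methoxy giving an at least 3.6-fold lower number from compound 1 to compound 4 (0.56 log units; beyond the scatter), iodo in place of chloro giving an at least 3.6-fold lower number from compound 3 to compound 4 (0.56 log units; beyond the scatter), and iodo in place of methyl giving an at least 3.6-fold lower number from compound 2 to compound 4 (0.56 log units; beyond the scatter). The group at this place can therefore move the result out of the limit, although methoxy, methyl and chloro do not, and each step gives only a minimum size, as its other end is a limit.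

Four groups at a single place cannot show why iodo differs from the other three, or whether bromo, the nearest halogen not among them, or an amine on the same carbon would also leave the limit. It also remains open how iodo would behave if the carboxylic acid at the end of the chain were replaced by an amide or a methyl ester, since every compound shown carries that same acid.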